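This account rests on a few compounds, and the source may have more. Where it says the series, first, only, none or still open, it means among the compounds named here.

Measured in a functional assay on MIA PaCa-2 cells (Homo sapiens) for inhibition, read by MTT assay, with a stated time of 3 days (a higher number here means a weaker inhibitor, a lower number a stronger inhibitor), where all three entries are limits of the assay and not numbers:

- Compound 1 `O=C([C@@H]1CCCN(S(=O)(=O)c2ccc(S(=O)(=O)N3CC[C@@H](O)C3)cc2)C1)N1CCC(F)(F)CC1`: > 3000 nM
- Compound 2 `CCN(CC)S(=O)(=O)c1ccc(S(=O)(=O)N2CCC[C@@H](C(=O)N3CCC(O)CC3)C2)cc1`: > 10000 nM
- Compound 3 `CCN(CC)S(=O)(=O)c1ccc(S(=O)(=O)N2CCC[C@@H](C(=O)N3CCC(C(F)(F)F)CC3)C2)cc1`: > 10000 nM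

Compound 2 stands at > 10000 nM, which is a limit. The same limit recurs across this small set: the limit of > 10000 nM in this assay, at which 2 of the 3 values shown sit. A second limit covers the remaining compound: the limit of > 3000 nM in this assay, at which 1 of the 3 values shown sits.

Compound 4 `CCN(CC)S(=O)(=O)c1ccc(S(=O)(=O)N2CCC[C@@H](C(=O)N[C@H]3CC[C@@H](OC)CC3)C2)cc1` has not yet been measured. It is reached from compound 2 by one change on a carbonyl carbon, with (4-methoxycyclohexyl)amino in place of 4-hydroxypiperidin-1-yl on a carbonyl carbon. The ring in the new group is carbon only, and the group brings defined stereocentres.

Going by the values given here, the only measured step that bears on this change is a step that the two limits leave unreadable from compound 2 to compound 3. It alters the same part of the molecule, but it has no readable size, so it gives no firm guide to size or direction in this assay. Compound 3 also gives a limit, > 10000 nM, so a weak result is the main expectation for compound 4.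

The expected change is an at least 2.0-fold lower number from compound 2 to compound 4 (0.30 log units; that floor lies within the scatter), a loose estimate with no measured size behind it.

For compound 4 the estimated value is 5000 nM, with an expected range of 500 nM to 20000 nM.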

Compound 4, half-maximal inhibitory concentration: > 10000 nM
Compound 4 ended at the assay's limit; the forecaster's own chance of this, stated with the estimate: 50%; middle value at least 2.0-fold (0.30 log units) from the limit.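

In this assay compound 4 gives > 10000 nM, which is a limit of the assay and not a number. The steps to compound 4 from compound 2 and from compound 3 have limits at both ends, and neither can be read. The compounds shown leave open how compound 2, compound 3 and compound 4 truly differ in this assay, and whether any group on this carbonyl carbon gives a measurable value.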